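Swapping Ethyl for Nitro at the Aromatic Carbon

The source may hold more compounds than are shown below. What is called first, only, known or untested is meant among the compounds shown, and "the series" means these compounds.

Measured so far:
compound 1 `CCCCCn1c(N)nc2c(OC)cccc21` — 3740 nM
compound 2 `CCCCCn1c(N)nc2c(Br)cccc21` — "not active" (no number reported)
compound 3 `CCCCCn1c(N)nc2c(CC)cccc21` — 1650 nM

In an assay on HEK293 cells for agonist activity at Toll-like receptor 8 (Homo sapiens), read by reporter gene assay (a lower number here means that less compound is needed, a higher number that more compound is needed for the effect), compound 3 gives 1650 nM, the lowest of the two numbers reported. Among the measured compounds shown here, its nearest neighbour is compound 1, and the only measured step is a 2.3-fold lower number from compound 1 to compound 3 (0.36 log units; beyond the scatter), a modest gain. Compound 2, carrying bromine at the same aromatic carbon, gives "not active" (no number reported).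

Compound 4 `CCCCCn1c(N)nc2c([N+](=O)[O-])cccc21` differs from compound 3 by nitro in place of ethyl on an aromatic carbon. For the measured compounds named here, no measured step involves a nitro group. Going by the values given here, the data show only that exchanging the group at this carbon shifts the number modestly, and that one exchange, to bromine, loses activity altogether. A modest step upward in this assay is therefore expected, a 2.7-fold higher number from compound 3 to compound 4 (0.44 log units; beyond the scatter), with a real chance of no activity. Compound 4 is estimated at 4500 nM, ranging from 1200 nM to 17000 nM.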

Compound 4, half-maximal effective concentration: "not active" (no number reported)
No number was reported for compound 4, so the estimate cannot be set against anything.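

Among the compounds shown here, compound 4 is reported as "not active" with no number, so no step from compound 3 to compound 4 can be read, and no evidence here bears on this result. The compounds shown leave open why compound 2 and compound 4 give no number while compound 1 and compound 3 do.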